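Coumarin-enaminone series: sulfonamide nitrogen substituent swap

The compounds below may be only part of what the source reports. "The series", "measured", "known", "first", "only" and "open" are said of these compounds alone.

For the measured compounds named here, compound 1 `CN(C)/C=C/C(=O)c1cc2ccccc2oc1=O` and compound 2 `NS(=O)(=O)c1ccc(N/C=C\C(=O)c2cc3ccccc3oc2=O)cc1` are the two measured members of this set. In a functional assay on T47D cells (Homo sapiens) for cytotoxicity, read by sulforhodamine B assay, with a stated time of 48 h (on this read-out higher numbers stand for weaker inhibition and lower numbers for stronger inhibition), compound 1 gives 147000 nM, and in this assay compound 2 gives 109000 nM; the two values lie within the usual scatter of one another, so nothing separates them. Compound 3 `CC(=O)NS(=O)(=O)c1ccc(N/C=C\C(=O)c2cc3ccccc3oc2=O)cc1` carries an acetyl on the sulfonamide nitrogen; in this assay compound 3 gives no result reported, so its place in the series is open. Compound 4 `N=C(N)NS(=O)(=O)c1ccc(N/C=C\C(=O)c2cc3ccccc3oc2=O)cc1` differs from compound 3 in one place: a group of 3 heavy atoms (1 carbon, 2 nitrogen; no ring) in place of a group of 3 heavy atoms (2 carbon, 1 oxygen; no ring), on a sulfonamide nitrogen, a group of three heavy atoms (one carbon, two nitrogen; no ring) in place of a group of three heavy atoms (two carbon, one oxygen; no ring), on a sulfonamide nitrogen. Going by the values given here, no step between measured compounds is available to size this change. Since compound 1 and compound 2 share the enaminone-coumarin core and read alike in this assay despite different terminal groups, no step beyond the scatter is expected in this assay on going to the guanidine. Compound 4 is accordingly estimated at 110000 nM in this assay, with a plausible range from 40000 nM to 300000 nM, and a fair chance that only a limit is reported.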

Compound 4, half-maximal inhibitory concentration: 87600 nM
The estimate for compound 4 lay 1.3-fold (0.10 log units) above the measured number; low and high end bracket the measured number.
By their numbers in this assay, from the lowest: compounds 4, 2 and 1 (each within the scatter of the next).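

In this assay, for the compounds shown here, the group of 3 heavy atoms (1 carbon, 2 nitrogen; no ring) on the sulfonamide nitrogen in place of a hydrogen atom gives a 1.2-fold lower number from compound 2 to compound 4 (0.09 log units; within the scatter), the first step that can be read at this position. Within this pair, adding the group to the sulfonamide nitrogen leaves the read-out indistinguishable from that of the unsubstituted sulfonamide, so this one change offers no handle on cytotoxicity in these cells. Nothing available bears on the reason for this result.

The step involving the acetyl group of compound 3 cannot be read, as compound 3 has no number. From the compounds shown here alone, whether a methyl, a longer alkyl chain or a chain ending in a carboxylic acid on the sulfonamide nitrogen would give a step beyond the scatter remains open.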